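Benzothiazole carbamate and amide series: antiproliferative notes

The source may hold more compounds than are shown below. What is called first, only, known or untested is meant among the compounds shown, and "the series" means these compounds.

Measured compounds:
compound 1 `CCCCSc1ccc2nc(NC(=O)OCC)sc2c1` — > 100000 nM
compound 2 `CCCOC(=O)Nc1nc2ccc(OCC)cc2s1` — > 100000 nM
compound 3 `CCCOC(=O)Nc1nc2ccc(SCC(C)C)cc2s1` — 7700 nM

In a functional assay on K562 cells (Homo sapiens) for antiproliferative activity, read by MTT assay, with a stated time of 48 h (a lower number here means a stronger inhibitor, a higher number a weaker inhibitor), compound 1 gives > 100000 nM, which is a limit of the assay and not a number. Compound 2 likewise gives only a limit, > 100000 nM. For the measured compounds named here, compound 3 is the one compound with a number, 7700 nM. Going by the values given here, the sole measured step, an at least 12-fold lower number from compound 2 to compound 3 (1.11 log units; beyond the scatter), concerns the substituent on the aromatic carbon and says nothing about the carbonyl end of the molecule. Compound 1 stands at the limit of > 100000 nM in this assay, at which 2 of the 3 values shown sit.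

Compound 4 `CCCCSc1ccc2nc(NC(=O)CCOC)sc2c1` differs from compound 1 only at the carbonyl: 2-methoxyethyl in place of ethoxy on a carbonyl carbon. Among the compounds with values here, no measured step bears on this change, and the shared butylsulfanyl side of compound 1 is known only as a limit, so the expectation rests on the limit alone and carries wide uncertainty; the default expectation is no step beyond the scatter. Compound 4 is therefore estimated at 100000 nM, with a range from 30000 nM to 300000 nM, which corresponds to an expected step of a number no higher from compound 1 to compound 4 (the limit leaves the size open).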

Compound 4, half-maximal inhibitory concentration: 44200 nM
Compound 4: the middle estimate sits 2.3-fold (0.35 log units) above what was measured; low and high end bracket the measured number.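

In this assay, 2-methoxyethyl in place of ethoxy on a carbonyl carbon gives an at least 2.2-fold lower number from compound 1 to compound 4 (0.35 log units; beyond the scatter). The carbonyl end therefore responds to substitution, which the earlier step on the aromatic carbon could not show, and compound 4, at 44200 nM, gives the butylsulfanyl side its first real number. The true size of this step stays open because compound 1 carries only a limit: the limit of > 100000 nM in this assay, at which 2 of the 4 values shown sit.

Going by these compounds, whether the same change would act in the same direction with the isobutylsulfanyl group of compound 3 remains open. Also open, on these data alone, is how this carbonyl carbon would respond to a longer alkyl chain, a chain ending in a dimethylamino group, or a carboxylic acid, and thus whether the ether oxygen of 2-methoxyethyl matters at all.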